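The source may hold more compounds than are shown below. What is called first, only, known or untested is meant among the compounds shown, and "the series" means these compounds.

Measured in a physicochemical assay for lipophilicity, read by HPLC, measured as octanol-water partition; a lower number here means a more polar compound, a higher number a more lipophilic compound:
Compound 1 `COc1ccc(N(CC(=O)NCCC[Te]c2ccccc2)C(=O)CNC(=O)OC(C)(C)C)cc1` gives 4.2.
Compound 2 `COc1ccc(N(CC(=O)NCCC[Se]c2ccccc2)C(=O)c2ccccc2)cc1` gives 3.1.
Compound 3 `COc1ccc(N(CC(=O)NCCC[Se]c2ccccc2)C(=O)CNC(=O)OC(C)(C)C)cc1` gives 3.3.

Compound 3 stands second highest of the three numbers in this assay. Its nearest neighbour is compound 2: the step of a number 0.20 log units higher from compound 2 to compound 3 (within the scatter) lies within the scatter, so no order between these two is claimed. The furthest is compound 1, and that step, a number 0.90 log units lower from compound 1 to compound 3 (beyond the scatter), is beyond the scatter and modest in size.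

Compound 4 `COc1ccc(N(CC(=O)NCCCSc2ccccc2)C(=O)CNC(=O)OC(C)(C)C)cc1` is not yet measured. Relative to compound 3 the change is a group of 7 heavy atoms (6 carbon, 1 sulfur; one six-membered aromatic ring of carbon only) in place of a group of 7 heavy atoms (6 carbon, 1 selenium; one six-membered aromatic ring of carbon only), on a saturated chain carbon, three bonds along the chain from an amide-type nitrogen. Among the measured compounds shown here, the only measured step bearing on it is the one in which the heavier chalcogen was replaced by the lighter one at the same place, a number 0.90 log units lower from compound 1 to compound 3 (beyond the scatter), a modest lowering. The present change is of the same kind, one step further down the same column, so a lowering in this assay is expected, probably no larger than that one, and possibly no more than the scatter. For compound 4 the value in this assay is estimated at 2.9, within 2.4 to 3.4. The expected step is therefore a number 0.40 log units lower from compound 3 to compound 4 (beyond the scatter).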

Compound 4, partition coefficient: 3.12
Beside the measured number, compound 4's estimate is 0.22 log units below it; low and high end bracket the measured number.
By their numbers in this assay, from the lowest: compounds 2, 4 and 3 (each within the scatter of the next); then compound 1.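

At this saturated chain carbon, three bonds along the chain from an amide-type nitrogen, phenylsulfanyl in place of the selenium-bearing group gives a number 0.18 log units lower from compound 3 to compound 4 (within the scatter) in this assay, so sulfur and selenium are not told apart at this position. Tellurium does stand apart from both, with a number 0.90 log units lower from compound 1 to compound 3 (beyond the scatter) and a number 1.08 log units lower from compound 1 to compound 4 (beyond the scatter), the latter being the largest step in the chalcogen set. Among the compounds shown here, of the two swaps down the column, then, only the one leaving tellurium lies beyond the scatter, and nothing at hand gives a reason for this.

Open, from the compounds shown here alone, is where an oxygen at the same place, as phenoxy, would fall, and whether a longer chain keeps tellurium apart. Also open, going by these compounds, is whether the same pattern holds with phenyl on the carbonyl carbon, where only the selenium compound 2 stands.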